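Lengthening an Alkoxy Group on a Nucleoside Transporter Inhibitor

The source may report more compounds than this note shows. Statements on the series, on what has been measured and on what is new or still open speak of the compounds shown alone.

Compound 1 `Nc1ncnc2c1nc(NCc1ccc(-c3ccncc3)cc1)n2[C@@H]1O[C@H](CO)[C@@H](O)[C@H]1O`: 2700 nM
Compound 2 `COc1cc(CNc2nc3c(N)ncnc3n2[C@@H]2O[C@H](CO)[C@@H](O)[C@H]2O)ccc1-c1ccccc1`: 1300 nM

Of the compounds shown here, two sharing the same core have been tested so far. In an assay on COS-7 cells for inhibition of sodium/nucleoside cotransporter 2 (Homo sapiens), read by scintillation counting (a higher number here means a weaker inhibitor, a lower number a stronger inhibitor), compound 1 gives 2700 nM, whereas compound 2 gives 1300 nM. Compound 2 therefore has the lowest number of the two, and the gap to compound 1 lies beyond the usual scatter, so compound 2 is the stronger inhibitor here.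

Compound 3 `CCCOc1cc(CNc2nc3c(N)ncnc3n2[C@@H]2O[C@H](CO)[C@@H](O)[C@H]2O)ccc1-c1ccccc1` has not yet been measured. It differs from compound 2 in one place: ethyl in place of hydrogen on a saturated chain carbon bound to an oxygen on an aromatic ring. Within the data shown here, no pair of measured compounds shows a change of this kind, so nothing in the data tells how large such a step is. The expectation is a small step, if any, with the number for compound 3 possibly a little lower than for compound 2 but plausibly within the scatter; the expected step is a 1.3-fold lower number from compound 2 to compound 3 (0.11 log units; within the scatter). Compound 3 is estimated to give 1000 nM in this assay, with a range from 300 nM to 3500 nM.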

Compound 3, half-maximal inhibitory concentration: 5200 nM
Compound 3: the middle estimate sits 5.2-fold (0.72 log units) below what was measured; the whole stated range lies below it.
By their numbers in this assay, from the lowest: compound 2; then compounds 1 and 3 (each within the scatter of the next).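

Among these compounds, measured in this assay the change from methoxy to propoxy gives a 4.0-fold higher number from compound 2 to compound 3 (0.60 log units; beyond the scatter) and this is the first reading of any change at this place. It shows that the group on this oxygen matters: with ethyl in place of hydrogen on the saturated chain carbon, compound 3 is a weaker inhibitor than compound 2, and the step lies beyond the usual scatter. No supporting measurement here accounts for this loss.

On these data alone, a single step gives two points and no trend, so it remains open whether an ethoxy group would fall between methoxy and propoxy, or whether a butoxy group would weaken inhibition further. As far as these compounds go, it also remains open whether a hydroxyl or an amine at the end of the propoxy chain would give a different result.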